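Oxime ether series: carboxy to hydroxy on the chain

This account rests on a few compounds, and the source may have more. Where it says the series, first, only, none or still open, it means among the compounds named here.

Measured compounds:
compound 1, `C/C(=N\OCC(N)=O)c1ccc(Cl)c(Cl)c1`, 55 mg/kg
compound 2, `C/C(=N\OCCC(=O)O)c1ccc(Cl)cc1`, 80 mg/kg

Both compounds were run in a functional assay on the whole organism for inhibition, with Rattus norvegicus as the target, read by paw edema, with stated times of 1 h and 3 h; a lower number here means that less compound is needed, a higher number that more compound is needed for the effect. Compound 1 gives 55 mg/kg and compound 2 gives 80 mg/kg. The gap between these two numbers lies within the usual scatter of this assay, so compound 2 is not separated from compound 1; neither compound can be said to need more or less than the other. Going by the values given here, no step between compounds that differ in a single place is available, so the series gives no measured step to lean on.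

Compound 3, `C/C(=N\OCCO)c1ccc(Cl)cc1`, has not been measured in this assay. It differs from compound 2 as follows: hydroxy in place of carboxy on a saturated chain carbon, two bonds along the chain from an oxygen. The chain that carries the group is otherwise unchanged.

With no measured step of this kind in hand, the step from compound 2 to compound 3 in this assay is expected to be small, with no clear direction and likely inside the scatter, so the estimated step is a 1.1-fold lower number from compound 2 to compound 3 (0.06 log units; within the scatter). Compound 3 is accordingly expected to give about 70 mg/kg in this assay, with a range from 30 mg/kg to 160 mg/kg.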

Compound 3, dose for half-maximal effect: 29 mg/kg
Compound 3: the middle estimate sits 2.4-fold (0.38 log units) above what was measured; the measured number lies below the stated range.
By their numbers in this assay, from the lowest: compounds 3, 1 and 2 (each within the scatter of the next, the first and the last beyond it).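

In this assay, going by these compounds alone, hydroxy in place of carboxy, on a saturated chain carbon, two bonds along the chain from an oxygen, gives a 2.8-fold lower number from compound 2 to compound 3 (0.44 log units; beyond the scatter) and provides the first measured single-place step. This position therefore responds to a change of the group at the chain end, although the step is modest. Carboxy is also not required here for activity in this assay, as compound 3 retains a measurable dose with hydroxy at the same place.

Going by these compounds, whether an amine or a methoxy group at this place, or a longer chain carrying the hydroxy, would read closer to compound 3 or to compound 2 remains open. Also open, on these data alone, is whether the same step holds on the core of compound 1, which differs from compound 2 in more than one place. No measured information is available to explain the step from carboxy to hydroxy.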